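Aryl sulfonate series: dimethylphenyl change on the propyl core

The compounds below may be only part of what the source reports. "The series", "measured", "known", "first", "only" and "open" are said of these compounds alone.

Compound 1 `COc1ccccc1OS(=O)(=O)c1ccc(N2CCN(C)C2=O)cc1` gives 26000 nM in a functional assay on MCF7 cells (Homo sapiens) for antiproliferative activity, read by sulforhodamine B assay, with a stated time of 48 h; on this read-out lower numbers stand for stronger inhibition and higher numbers for weaker inhibition. Compound 2 `Cc1ccc(OS(=O)(=O)c2ccc(N3CCN(C)C3=O)cc2)c(C)c1` gives 2500 nM in this assay, and compound 3 `CCCN1CCN(c2ccc(S(=O)(=O)Oc3ccccc3OC)cc2)C1=O` gives 13000 nM. The change from compound 1 to compound 2 is 2,4-dimethylphenyl in place of 2-methoxyphenyl on an oxygen, and it brings a 10-fold lower number from compound 1 to compound 2 (1.02 log units; beyond the scatter). The two cores differ as ethyl in place of hydrogen on a saturated chain carbon bound to an amide-type nitrogen in a ring, which gives a 2.0-fold lower number from compound 1 to compound 3 (0.30 log units; within the scatter). Compound 4 `CCCN1CCN(c2ccc(S(=O)(=O)Oc3ccc(C)cc3C)cc2)C1=O` carries the same change on the core of compound 3: 2,4-dimethylphenyl in place of 2-methoxyphenyl on an oxygen. The place is described in the same words for both pairs, so this is the same change, seen once so far; whether it transfers unchanged to the core of compound 3 is not known. Compound 4 is expected to show an 8.7-fold lower number from compound 3 to compound 4 (0.94 log units; beyond the scatter), a step taken as close to the earlier one because the same change gave a 10-fold lower number from compound 1 to compound 2 (1.02 log units; beyond the scatter). The estimate for compound 4 is 1500 nM, with a range from 500 nM to 5000 nM.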

Compound 4, half-maximal inhibitory concentration: 1500 nM
The estimate for compound 4 equals the measured number at the digits printed; the range from low to high includes it.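

In this assay, 2,4-dimethylphenyl in place of 2-methoxyphenyl carries over to the second core with an 8.7-fold lower number from compound 3 to compound 4 (0.94 log units; beyond the scatter), and this step matches the earlier one: the same change on two cores in this assay, a 10-fold lower number (1.02 log units; beyond the scatter) from compound 1 to compound 2 and an 8.7-fold lower number (0.94 log units; beyond the scatter) from compound 3 to compound 4, 1.2-fold (0.08 log units) apart, within the scatter of two such steps. The core change, ethyl in place of hydrogen, reads a 1.7-fold lower number from compound 2 to compound 4 (0.22 log units; within the scatter) with 2,4-dimethylphenyl on the oxygen, and it also agrees with its earlier step: the same change on two cores in this assay, a 2.0-fold lower number (0.30 log units; within the scatter) from compound 1 to compound 3 and a 1.7-fold lower number (0.22 log units; within the scatter) from compound 2 to compound 4, 1.2-fold (0.08 log units) apart, within the scatter of two such steps. This shows the two changes acting independently across these four compounds only; it rests on two cores and one pair of aryl groups and does not show why the step arises or that it holds on any other core.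

Still open, as far as these compounds go, is whether the step persists with a different aryl group, such as a chlorophenyl or a cyanophenyl. Also open, from the compounds shown here alone, is whether it persists when the chain on the ring nitrogen is longer or ends in an amine.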